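The compounds below may be only part of what the source reports. "The series", "measured", "known", "first", "only" and "open" are said of these compounds alone.

Measured in a functional assay on HCC 2998 cells (Homo sapiens) for antiproliferative activity, read by sulforhodamine B assay, with a stated time of 48 h; a higher number here means a weaker inhibitor, a lower number a stronger inhibitor
Compound 1 `O=C(NCCCNc1cc(-c2cn(-c3ccccc3)nc2-c2cccc(O)c2)ccn1)Nc1ccc(F)cc1` gives 1090 nM
Compound 2 `O=C(NCCCNc1cc(-c2cn(-c3ccccc3)nc2-c2cccc(O)c2)ccn1)Nc1cccc(C(F)(F)F)c1` gives 1260 nM

Only these two numbers are available, and they do not separate. Among the compounds with values here, the single step that joins them is a 1.2-fold higher number from compound 1 to compound 2 (0.06 log units; within the scatter) and so compound 1 stands level with its only measured neighbour, in the low micromolar range.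

Compound 3 `COc1cccc(-c2nn(-c3ccccc3)cc2-c2ccnc(NCCCNC(=O)Nc3ccc(F)cc3)c2)c1` keeps the core of compound 1 and alters one group. The change is methyl in place of hydrogen on an oxygen on an aromatic ring and it turns hydroxy to methoxy, or 3-hydroxyphenyl to 3-methoxyphenyl.

The measured step bears on this only indirectly. Within the data shown here, it replaced 4-fluorophenyl at the other end of the molecule and left the hydroxy group untouched, so the data hold no direct precedent for the new methyl and fix no direction. A modest step in this assay is expected, leaning slightly towards a higher number, with a wide margin on both sides. The expected change is a 1.4-fold higher number from compound 1 to compound 3 (0.14 log units; within the scatter) and no more than that is claimed. For compound 3 the estimated value is 1500 nM with an expected range from 600 nM to 4000 nM in this assay's terms.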

Compound 3, half-maximal inhibitory concentration: 7380 nM
Estimate against measurement, compound 3: 4.9-fold (0.69 log units) below; the whole stated range lies below it.
By their numbers in this assay, from the lowest: compounds 1 and 2 (each within the scatter of the next); then compound 3.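

In this assay, the change on the oxygen of the 3-hydroxyphenyl group gives a 6.8-fold higher number from compound 1 to compound 3 (0.83 log units; beyond the scatter) and this step lies beyond the scatter. Within the data shown here, the only earlier step, a 1.2-fold higher number from compound 1 to compound 2 (0.06 log units; within the scatter), changed the other end of the molecule and stayed within the scatter, so this is the first sign in these data that a single change can move the number measurably, and here a methyl in place of a hydrogen on the oxygen moves it upward. No measurement is at hand that explains this shift.

As far as these compounds go, a single pair cannot show whether the step follows from losing the hydroxy hydrogen or from gaining the methyl, and how an ethoxy group, an amine or a fluorine in the same place would compare remains open. From the compounds shown here alone, it is also open whether methoxy in place of hydroxy would give a step of similar size with the 3-(trifluoromethyl)phenyl group of compound 2 at the other end of the molecule.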